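Proline Amide to Aminocyclohexyl Amide on a Shared Core

This account rests on a few compounds, and the source may have more. Where it says the series, first, only, none or still open, it means among the compounds named here.

Measured so far in an assay on isolated protein for inhibition of Rho-associated protein kinase 2 (Homo sapiens); a higher number here means a weaker inhibitor, a lower number a stronger inhibitor:
compound 1 `CC(C)[C@@H](N)C(=O)Nc1cc2cc[nH]c(=O)c2cc1Cl` gives 240 nM
compound 2 `O=C(Nc1cc2cc[nH]c(=O)c2cc1Cl)[C@@H]1CCCN1` gives 35 nM

Among the compounds with values here, compound 2 holds the lower of the two numbers; its only measured neighbour is compound 1, and the one step recorded, a 6.9-fold lower number from compound 1 to compound 2 (0.84 log units; beyond the scatter), lies beyond the scatter. Compound 3 `N[C@H]1CC[C@@H](C(=O)Nc2cc3cc[nH]c(=O)c3cc2Cl)CC1` differs from compound 2 in a single place: 4-aminocyclohexyl in place of pyrrolidin-2-yl on a carbonyl carbon. The measured step does not test this particular exchange. Within the data shown here, it shows only that swapping the group on the carbonyl carbon can shift the number by a modest amount, in either direction as far as these two compounds tell. With no closer guide, the expected change is small. In this assay compound 3 is estimated at 60 nM, with a range from 15 nM to 250 nM, which corresponds to an expected step of a 1.7-fold higher number from compound 2 to compound 3 (0.23 log units; within the scatter), within the scatter.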

Compound 3, half-maximal inhibitory concentration: 15 nM
Estimate against measurement, compound 3: 4.0-fold (0.60 log units) above; measured number inside the range.
By their numbers in this assay, from the lowest: compound 3; then compound 2; then compound 1.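

In this assay, the group on the carbonyl carbon need not be pyrrolidin-2-yl to give a low number: the larger 4-aminocyclohexyl does better (a 2.3-fold lower number from compound 2 to compound 3 (0.37 log units; beyond the scatter)). Measured against the open-chain 1-amino-2-methylpropyl group, the change is large (a 16-fold lower number from compound 1 to compound 3 (1.20 log units; beyond the scatter)), so the choice of group at this one place clearly moves the number. Nothing available explains why the six-membered carbon ring outdoes the five-membered ring.

The compounds shown leave open whether the amine on the ring is needed at all, which a plain cyclohexyl group, or a cyclohexyl ring carrying a hydroxyl group or an aminomethyl group instead, would test. They also leave open whether the other stereoisomer of 4-aminocyclohexyl gives a similar number.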